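Swapping the amine hydrogen of compound 3 for an aryl amidine

This account rests on a few compounds, and the source may have more. Where it says the series, first, only, none or still open, it means among the compounds named here.

Three compounds sharing one core were tested in a functional assay on HepG2 cells (Homo sapiens) for inhibition, read by MTT assay, with a stated time of 48 h; a lower number here means a stronger inhibitor, a higher number a weaker inhibitor. Compound 1 `CCOC(=O)C1=C(N/C=N/c2cccnc2Cl)Nc2[nH]nc(C)c2C1c1ccc(N(C)C)cc1` gives 4890 nM, compound 2 `CCOC(=O)C1=C(N/C=N/c2ccccn2)Nc2[nH]nc(C)c2C1c1ccc(N(C)C)cc1` gives 26200 nM, and compound 3 `CCOC(=O)C1=C(N)Nc2[nH]nc(C)c2C1c1ccc(N(C)C)cc1`, which carries a free amine on the core, gives 4240 nM. Compound 3 has the lowest number of the three, but its gap to compound 1 lies within the scatter, so the two cannot be ranked; only compound 2 is clearly weaker.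

Compound 4 `CCOC(=O)C1=C(N/C=N/c2ccc(C)cc2)Nc2[nH]nc(C)c2C1c1ccc(N(C)C)cc1` differs from compound 3 in one place: a group of 9 heavy atoms (8 carbon, 1 nitrogen; one six-membered aromatic ring of carbon only) in place of a hydrogen atom, on an amine nitrogen. Among the compounds with values here, two measured steps bear on this, both of them stripping a similar aryl-bearing group from the same amine nitrogen down to hydrogen. The step of a 1.2-fold lower number from compound 1 to compound 3 (0.06 log units; within the scatter) shows that a chloropyridyl group on that nitrogen changes nothing beyond the scatter, whereas the step of a 6.2-fold lower number from compound 2 to compound 3 (0.79 log units; beyond the scatter) shows that a plain pyridyl group costs a modest amount of potency. Within the data shown here, the group entering in compound 4 is an all-carbon ring with a methyl, for which no direct precedent exists here, so the outcome is uncertain within that span.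

Compound 4 is therefore expected to fall between those two cases, at a 2.1-fold higher number from compound 3 to compound 4 (0.33 log units; beyond the scatter), giving an estimated 9000 nM with a range from 3000 nM to 27000 nM.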

Compound 4, half-maximal inhibitory concentration: 44400 nM
Beside the measured number, compound 4's estimate is 4.9-fold (0.69 log units) below it; measured number outside the range, above it.
By their numbers in this assay, from the lowest: compounds 3 and 1 (each within the scatter of the next); then compounds 2 and 4 (each within the scatter of the next).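

Placing the 4-methylphenyl amidine on the amine nitrogen gives a 10-fold higher number from compound 3 to compound 4 (1.02 log units; beyond the scatter) in this assay, so this position can lose far more potency than compound 1 or compound 2 had suggested. The carbon-only ring with its methyl and the pyridin-2-yl ring cannot be told apart, with a 1.7-fold higher number from compound 2 to compound 4 (0.23 log units; within the scatter) lying within the scatter, whereas a 9.1-fold higher number from compound 1 to compound 4 (0.96 log units; beyond the scatter) sets the 2-chloropyridin-3-yl group clearly apart, making compound 1 the only one of the three aryl amidines that cannot be separated from the free amine of compound 3. Nothing available here explains why that one aryl group differs from the other two.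

The 2-chloropyridin-3-yl group differs from the other two in both its chlorine and the way its ring is built, so a chlorophenyl ring or a pyridine ring without chlorine would be needed to show which feature matters. On these data alone, it also remains open whether any group on this nitrogen, such as a simple alkyl chain or an acetyl group, can give a number clearly lower than that of compound 3.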